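Compound 1 and its piperidin-1-yl counterpart

A few compounds are considered here, and "the series" means these few. Any claim that something is new, unique, unknown or untested is made for them only; others in the source may bear on it.

In a toxicity assay on L02 cells (Homo sapiens) for cytotoxicity, read by MTT assay, with a stated time of 72 h (on this read-out lower numbers stand for stronger inhibition and higher numbers for weaker inhibition), compound 1 `O=C1c2c[n+]([O-])c3ccccc3c2C(=O)c2c1c1ccccc1n2CCCCn1ccnc1` gives 150 nM, the lowest of the three numbers measured. Compound 2 `CC1(C)O[C@@H](CO)[C@H](Cn2cc(Cn3c4c(c5ccccc53)C(=O)c3c[n+]([O-])c5ccccc5c3C4=O)nn2)O1` gives 500 nM, and compound 3 `CC1(C)OC[C@@H](Cn2cc(Cn3c4c(c5ccccc53)C(=O)c3c[n+]([O-])c5ccccc5c3C4=O)nn2)O1` gives 2900 nM. Compound 4 `O=C1c2c[n+]([O-])c3ccccc3c2C(=O)c2c1c1ccccc1n2CCCCN1CCCCC1` differs from compound 1 as follows: piperidin-1-yl in place of 1H-imidazol-1-yl on a saturated chain carbon, four bonds along the chain from an aromatic nitrogen. That is, piperidin-1-yl stands in place of 1H-imidazol-1-yl on a saturated chain carbon. Going by the values given here, no measured step covers this swap. Among the compounds with values here, the only single change measured is a 5.8-fold higher number from compound 2 to compound 3 (0.76 log units; beyond the scatter), a modest step at another group, so it offers only a rough guide to size. A similarly modest rise is therefore expected, and the expected step is a 2.1-fold higher number from compound 1 to compound 4 (0.33 log units; beyond the scatter). For compound 4 the estimated value is 320 nM, with an expected range of 90 nM to 1200 nM.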

Compound 4, half-maximal inhibitory concentration: 610 nM
Compound 4: middle estimate off by 1.9-fold (0.28 log units), on the low side; low and high end bracket the measured number.
By their numbers in this assay, from the lowest: compound 1; then compounds 2 and 4 (each within the scatter of the next); then compound 3.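

In this assay, piperidin-1-yl in place of 1H-imidazol-1-yl on a saturated chain carbon, four bonds along the chain from an aromatic nitrogen, gives a 4.1-fold higher number from compound 1 to compound 4 (0.61 log units; beyond the scatter). Going by these compounds alone, this shows that the number responds to the group at this place, with the core and chain unchanged, which the earlier compounds did not show. Nothing available explains the rise. On these data alone, how morpholin-4-yl, an open-chain diethylamino group or a longer chain would read at this place stays open.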